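The source may hold more compounds than are shown below. What is called first, only, known or untested is meant among the compounds shown, and "the series" means these compounds.

Working notes on the series. Compound 1 `N#CN/C(=N\CCOC(=O)c1ccccc1)NCCCOc1cccc(CN2CCCCC2)c1` is measured in a functional assay on cardiac atrium for antagonist activity at histamine H2 receptor (Cavia porcellus) (a higher number here means a more potent compound, by a factor of ten per unit of this negative logarithm, a lower number a less potent compound), at 7.64, the higher of the two numbers recorded. Compound 2 `Nc1ccc(C(=O)NCCCOc2cccc(CN3CCCCC3)c2)cc1`, which carries an amide of an aminobenzoic acid on the shared propoxy chain in place of the cyanoguanidine arm, gives in this assay 6.82; the two values lie beyond the scatter of each other, with compound 1 the higher. For the measured compounds named here, no step between measured compounds differing in one place is recorded.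

Compound 3 `N#CN/C(=N\CCNC(=O)c1ccc(N=[N+]=[N-])cc1)NCCCOc1cccc(CN2CCCCC2)c1` is not yet measured. Relative to compound 1 the change is ((4-azidophenyl)carbonyl)amino in place of benzoyloxy on a saturated chain carbon, two bonds along the chain from a double-bonded nitrogen: in words, ((4-azidophenyl)carbonyl)amino in place of benzoyloxy on a saturated chain carbon, two bonds along the chain from a double-bonded nitrogen. The cyanoguanidine arm and the piperidinylmethyl-phenoxy part of compound 1 remain. The measured pair gives no direct guide for an ester-to-amide exchange at this position, and the azido group is new to the series. Compound 3 is expected to stay close to compound 1, with the step from compound 1 to compound 3 estimated as a number 0.14 log units lower from compound 1 to compound 3 (within the scatter), within the scatter. For compound 3 in this assay the estimate is 7.5, with a range from 6.8 to 8.2.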

Compound 3, negative logarithm of the antagonist equilibrium constant: 7.9
Beside the measured number, compound 3's estimate is 0.40 log units below it, and the stated range covers the measured number.
By their numbers in this assay, from the lowest: compound 2; then compounds 1 and 3 (each within the scatter of the next).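

In this assay the exchange of benzoyloxy for ((4-azidophenyl)carbonyl)amino gives a number 0.26 log units higher from compound 1 to compound 3 (within the scatter), so this position takes the new group, with 12 heavy atoms against 9 and one hydrogen-bond donor against none, with no difference beyond the scatter. The earlier compounds shown here did not show this, as they offered no step at this place and no azido group. No measured evidence on hand bears on a reason for this result.

The step changes the ester to an amide and adds the azido group together, and the compounds shown do not separate the two. Open, therefore, is how an unsubstituted benzoylamino group, an amine in place of the azido group, or a longer chain at this place would compare.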